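Swapping the amine ring at the end of the propyl chain

The source may hold more compounds than are shown below. What is called first, only, known or untested is meant among the compounds shown, and "the series" means these compounds.

Among the compounds with values here, compound 3 `N[C@@H]1CCN(CCCOc2ccc(-c3nc4ccc(Oc5ccc(Cl)cc5)cc4o3)cc2)C1` stands second highest of the three numbers known in an assay on isolated protein for inhibition of advanced glycosylation end product-specific receptor (Homo sapiens), read by FRET, with stated times of 30 min and 1 h, tested at 4 uM (on this read-out lower numbers stand for less inhibition and higher numbers for more inhibition at the one concentration tested (going by the name of the read-out)), where compound 3 gives 19.6%. Compound 1 `Clc1ccc(Oc2ccc3nc(-c4ccc(OC5CCNCC5)cc4)oc3c2)cc1` gives 20.6% in this assay, and compound 2 `CCN1CCC(Oc2ccc(-c3nc4ccc(Oc5ccc(Cl)cc5)cc4o3)cc2)CC1` gives 15.3%. Neither sits apart from compound 3 beyond the scatter: the steps were a number 1 percentage points lower from compound 1 to compound 3 (within the scatter) and a number 4.3 percentage points higher from compound 2 to compound 3 (within the scatter). The step between the two earlier compounds, a number 5.3 percentage points lower from compound 1 to compound 2 (within the scatter), was likewise small.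

Compound 4 `Clc1ccc(Oc2ccc3nc(-c4ccc(OCCCN5CCNCC5)cc4)oc3c2)cc1` differs from compound 3 only at the far end of the chain: piperazin-1-yl in place of 3-aminopyrrolidin-1-yl on a saturated chain carbon, three bonds along the chain from an oxygen on an aromatic ring. The three measured steps all concern changes to the amine-bearing end of the molecule and none of them moved the read-out beyond the scatter, so they give no reason to expect a different outcome here. The step expected in this assay is therefore a number 1.6 percentage points lower from compound 3 to compound 4 (within the scatter), nothing beyond the scatter. Compound 4 is accordingly expected to give about 18%, within a range from 8% to 28%.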

Compound 4, a percentage reported as inhibition, at one concentration (the size of the read-out at that concentration, not a potency): 42.7%
For compound 4 the middle estimate is 24.7 percentage points below the measured one; measured number above the stated range.
By their numbers in this assay, from the lowest: compounds 2, 3 and 1 (each within the scatter of the next); then compound 4.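

In this assay, the position at the end of the propyl chain proves sensitive to the amine ring: piperazin-1-yl in place of 3-aminopyrrolidin-1-yl, with the same atoms joined differently and the same counts of donors and acceptors, gives a step beyond the scatter (a number 23.1 percentage points higher from compound 3 to compound 4 (beyond the scatter)). The 3-(piperazin-1-yl)propyl group also stands clear of piperidin-4-yl (a number 22.1 percentage points higher from compound 1 to compound 4 (beyond the scatter)) and 1-ethylpiperidin-4-yl (a number 27.4 percentage points higher from compound 2 to compound 4 (beyond the scatter)) on the same oxygen, so the earlier flat numbers did not hold for every amine at this end of the molecule. Nothing given here accounts for this rise.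

The compounds shown leave open whether 4-methylpiperazin-1-yl or morpholin-4-yl on the propyl chain would keep this gain. They also leave open how piperazin-1-yl would fare on a shorter ethyl or longer butyl chain.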